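Benzyl in place of methyl on an unchanged thiazole-imidazole core

The source may report more compounds than this note shows. Statements on the series, on what has been measured and on what is new or still open speak of the compounds shown alone.

Compound 1 `CCOC(=O)c1sc(-c2nc3ccccc3n2C)nc1C` in a functional assay on MCF7 cells (Homo sapiens) for cytotoxicity, read by MTT assay, with a stated time of 24 h (a lower number here means a stronger inhibitor, a higher number a weaker inhibitor), gives > 20000 nM, a limit of the assay.
Compound 2 `CCOC(=O)c1sc(-c2nc3ccccc3n2CC)nc1C` in this assay gives > 20000 nM, also a limit.
Compound 3 `CCOC(=O)c1csc(-c2nc3ccccc3n2C)n1` in this assay gives > 20000 nM, again a limit.

Compound 3 therefore sits where all three measured values sit, namely at the limit of > 20000 nM in this assay, at which 3 of the 3 values shown sit; no number is known for it. Compound 4 `CCOC(=O)c1csc(-c2nc3ccccc3n2Cc2ccccc2)n1` carries phenyl in place of hydrogen on a saturated chain carbon bound to an aromatic nitrogen. Among the compounds with values here, the only measured step at this place, a step that the two limits leave unreadable from compound 1 to compound 2, is itself hidden by the limits, so no size or direction can be read from it. The shown values give no reason to expect compound 4 to move past the limit, and a step that the limit leaves unreadable from compound 3 to compound 4 is the expected step. Compound 4 is estimated at 30000 nM, within 10000 nM to 100000 nM.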

Compound 4, half-maximal inhibitory concentration: > 20000 nM
Compound 4 was reported as a limit (the forecaster's own chance of this, stated with the estimate: 85%); the middle value is on the limit's open side.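

No step can be read from compound 3 to compound 4, since each gives only a limit: the limit of > 20000 nM in this assay, at which 4 of the 4 values shown sit. The compounds shown leave open whether they differ at all in strength, including whether methyl to benzyl changes anything.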